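This account rests on a few compounds, and the source may have more. Where it says the series, first, only, none or still open, it means among the compounds named here.

Measured compounds, cytotoxicity on A549 cells:
- compound 1, `CN(C)CCn1cnnc1-c1cc(Oc2ccc(NC(=O)N/N=C/c3c[nH]c4ccccc34)cc2F)ccn1`: compound 1 gives 820 nM in a functional assay on A549 cells (Homo sapiens) for cytotoxicity, read by MTT assay, with a stated time of 72 h; on this read-out higher numbers stand for weaker inhibition and lower numbers for stronger inhibition
- compound 2, `COc1ccc(/C=N/NC(=O)Nc2ccc(Oc3ccnc(-c4nncn4CCN(C)C)c3)c(F)c2)c(OC)c1`: compound 2 gives 2820 nM in this assay
- compound 3, `Cn1ncnc1-c1cc(Oc2ccc(NC(=O)N/N=C/c3ccccc3)cc2F)ccn1`: for compound 3 this assay reports only a limit, > 100000 nM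

Within the data shown here, compound 2 carries the highest of the two numbers in this assay; its nearest neighbour is compound 1, and the one further value is a limit, not a number (the limit of > 100000 nM in this assay, at which 1 of the 3 values shown sits). Among the measured compounds shown here, the single step in the set runs a 3.4-fold higher number from compound 1 to compound 2 (0.54 log units; beyond the scatter); that step exchanges the aryl group on the carbon with a double bond to nitrogen and is the only direct evidence for what a swap at this position does.

Compound 4, `CN(C)CCn1cnnc1-c1cc(Oc2ccc(NC(=O)N/N=C/c3cccc(Cl)c3Cl)cc2F)ccn1`, has not yet been tested in this assay. Its change from compound 2 is 2,3-dichlorophenyl in place of 2,4-dimethoxyphenyl on a carbon with a double bond to nitrogen. For the measured compounds named here, the measured step bearing on it is a 3.4-fold higher number from compound 1 to compound 2 (0.54 log units; beyond the scatter), a modest shift when the aryl group was replaced; no step with a chlorinated aryl group is available. A change of similar modest size is therefore expected, with the direction uncertain, so the estimate for compound 4 is placed near compound 2 with a wide range, giving an expected value of 2000 nM (range 600 nM to 7000 nM). The expected step is a 1.4-fold lower number from compound 2 to compound 4 (0.15 log units; within the scatter), estimated as within or just beyond the scatter.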

Compound 4, half-maximal inhibitory concentration: 1090 nM
Estimate against measurement, compound 4: 1.8-fold (0.26 log units) above, within the range that was stated.
By their numbers in this assay, from the lowest: compounds 1 and 4 (each within the scatter of the next); then compound 2. At a limit, above all of these: compound 3.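

In this assay, the exchange of 2,4-dimethoxyphenyl for 2,3-dichlorophenyl on the carbon with a double bond to nitrogen gives a 2.6-fold lower number from compound 2 to compound 4 (0.41 log units; beyond the scatter), so this position responds to a change between two substituted phenyl groups and not only to the exchange of 1H-indol-3-yl seen earlier. The exchange of 1H-indol-3-yl for 2,3-dichlorophenyl gives a 1.3-fold higher number from compound 1 to compound 4 (0.12 log units; within the scatter), which leaves these two groups indistinguishable here and, among the three compounds that can be compared, sets 2,4-dimethoxyphenyl apart as the group with the highest number, while also showing that a group without hydrogen-bond donors or acceptors can match 1H-indol-3-yl at this position. Nothing at hand gives a measured property that would explain either step.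

On these data alone, it remains open whether the two chlorines are both needed, or whether their placement matters, as a single chlorine, a 3,4-dichlorophenyl group or a carboxylic acid on the phenyl ring could show. As far as these compounds go, for compound 3 the assay gives only a limit, > 100000 nM, and since compound 3 differs from the others in more than one place, the role of the dimethylaminoethyl chain also stays open.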